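Step from compound 3 to compound 4

The compounds below may be only part of what the source reports. "The series", "measured", "known", "first", "only" and "open" are said of these compounds alone.

In a functional assay on HL-60 cells (Homo sapiens) for inhibition, read by CCK-8 assay, with a stated time of 48 h (a lower number here means a stronger inhibitor, a higher number a weaker inhibitor), compound 3 (`Cc1ccc(-c2ccsc2S(=O)(=O)NCCNC(=S)Nc2cccc([N+](=O)[O-])c2)c(Oc2ccc(O)c(O)c2)c1`) gives 3400 nM, compound 2 (`Cc1ccc(-c2ccsc2S(=O)(=O)NCCNC(=O)Nc2cc(Cl)cc(Cl)c2)c(Oc2ccc(O)c(O)c2)c1`) gives 3500 nM and compound 1 (`COc1ccc(NC(=O)NCCNS(=O)(=O)c2sccc2-c2ccc(C)cc2Oc2ccc(O)c(O)c2)cc1`) gives 6100 nM, so all three lie within the scatter of one another. Compound 4 (`Cc1ccc(-c2ccsc2S(=O)(=O)NCCNC(=O)Nc2cccc([N+](=O)[O-])c2)c(Oc2ccc(O)c(O)c2)c1`) carries (3-nitrophenyl)carbamoyl on an amine nitrogen: a group of 12 heavy atoms (7 carbon, 2 nitrogen, 3 oxygen; one six-membered aromatic ring of carbon only) in place of a group of 12 heavy atoms (7 carbon, 2 nitrogen, 2 oxygen, 1 sulfur; one six-membered aromatic ring of carbon only), on an amine nitrogen. Within the data shown here, no measured step isolates this exchange of sulfur for oxygen. The nearest evidence is a 1.7-fold lower number from compound 1 to compound 2 (0.24 log units; within the scatter), a 1.8-fold lower number from compound 1 to compound 3 (0.25 log units; within the scatter) and a 1.0-fold lower number from compound 2 to compound 3 (0.01 log units; within the scatter), each within the scatter, and the last two change the aromatic part as well. No shift beyond the scatter is expected, and the expected size is a 1.1-fold higher number from compound 3 to compound 4 (0.05 log units; within the scatter). Compound 4 is estimated at 3800 nM, with an expected range of 1900 nM to 7500 nM.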

Compound 4, half-maximal inhibitory concentration: 6000 nM
Compound 4: the middle estimate sits 1.6-fold (0.20 log units) below what was measured, within the range that was stated.
By their numbers in this assay, from the lowest: compounds 3, 2, 4 and 1 (each within the scatter of the next).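

In this assay the exchange of sulfur for oxygen on the amine nitrogen now stands alone, and a 1.8-fold higher number from compound 3 to compound 4 (0.25 log units; within the scatter) stays within the scatter. With oxygen kept, the aryl exchanges also stay within it, as a 1.7-fold higher number from compound 2 to compound 4 (0.23 log units; within the scatter) and a 1.0-fold lower number from compound 1 to compound 4 (0.01 log units; within the scatter) show. No measurement bearing on these steps is available.

Going by these compounds, whether the sulfur for oxygen exchange reads the same with 3,5-dichlorophenyl or 4-methoxyphenyl remains open. Also open, on these data alone, is whether an aminophenyl or carboxyphenyl group, or a longer chain, would give a step beyond the scatter.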